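This account rests on a few compounds, and the source may have more. Where it says the series, first, only, none or still open, it means among the compounds named here.

Of the compounds shown here, three sharing one core have been measured in a functional assay on MGC-803 cells (Homo sapiens) for antiproliferative activity, read by CCK-8 assay, with a stated time of 72 h, tested at 8 uM; a lower number here means a weaker effect, a higher number a stronger effect of the compound at the concentration tested. Compound 1 `CC1CCCCN1C(=S)SCc1ccc(C(=O)Nc2ccccc2N)cc1` gives 86.9%. Compound 2 `Nc1ccccc1NC(=O)c1ccc(CSC(=S)N2CCN(c3ccncc3)CC2)cc1` gives 87.1% in this assay, the highest of the three numbers, yet compound 1 lies within the scatter of it, as does compound 3 `Nc1ccccc1NC(=O)c1ccc(CSC(=S)N2CCCC2)cc1`, which gives 83.4% in this assay. Within the data shown here, the single step that alters one place is a number 3.5 percentage points lower from compound 1 to compound 3 (within the scatter), showing that exchanging the ring on the thiocarbonyl carbon keeps the read-out within the scatter.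

Compound 4 `Cc1ccc(N2CCN(C(=S)SCc3ccc(C(=O)Nc4ccccc4N)cc3)CC2)cc1` has not yet been measured. It differs from compound 2 in one place: 4-methylphenyl in place of pyridin-4-yl on an amine nitrogen in a ring. Among the measured compounds shown here, no measured step touches this position; the only known step, between compound 1 and compound 3, concerns a different part of the molecule and stayed within the scatter. With all three measured numbers grouped so tightly, nothing in the data points toward a step beyond the scatter in this assay. The account therefore expects a number 2.1 percentage points lower from compound 2 to compound 4 (within the scatter) to be small. Compound 4 is estimated to give 85% in this assay, with an expected range from 74% to 93%.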

Compound 4, a percentage reported as inhibition, at one concentration (the size of the read-out at that concentration, not a potency): 19.8%
Beside the measured number, compound 4's estimate is 65.2 percentage points above it; the whole stated range lies above it.
By their numbers in this assay, from the lowest: compound 4; then compounds 3, 1 and 2 (each within the scatter of the next).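

In this assay, among these compounds, the group on the amine nitrogen of the six-membered non-aromatic ring with 2 nitrogen proves decisive: 4-methylphenyl in place of pyridin-4-yl gives a number 67.3 percentage points lower from compound 2 to compound 4 (beyond the scatter), whereas the only earlier step, at the ring on the thiocarbonyl carbon, stayed within the scatter. Among the compounds shown here, the read-out that looked flat across the earlier compounds is therefore not indifferent to every change on this scaffold, and one exchange at this position, of a six-membered aromatic ring with 1 hetero atom for a methyl-bearing aromatic ring of carbon only, separates two otherwise identical compounds by a large margin. No measurement at hand accounts for this step, so what produces it remains unexplained.

As far as these compounds go, it remains open whether the drop follows from losing the ring nitrogen or from gaining the methyl, a question that a plain phenyl on the same nitrogen would help to settle. Pyridin-3-yl and pyridin-2-yl at this place would further show whether the location of the ring nitrogen matters as well as its presence.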